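Methoxy added beside the benzyloxy arm of a hydroxamic acid

A few compounds are considered here, and "the series" means these few. Any claim that something is new, unique, unknown or untested is made for them only; others in the source may bear on it.

Compound 1 `CCCCCCc1ccc(COc2cccc(C(=O)NO)c2)cc1` gives 3380 nM in an assay on isolated protein for inhibition of sphingomyelin phosphodiesterase (Homo sapiens), read by fluorescence, with a stated time of 30 min; a higher number here means a weaker inhibitor, a lower number a stronger inhibitor. Compound 2 `O=C(NO)c1cccc(OCc2ccc(-c3ccc(Cl)cc3)cc2)c1` gives 360 nM, the lowest of the two numbers; the step of a 9.4-fold lower number from compound 1 to compound 2 (0.97 log units; beyond the scatter) separates them. Compound 3 `COc1ccc(C(=O)NO)cc1OCc1ccc(-c2ccc(Cl)cc2)cc1` carries methoxy in place of hydrogen on an aromatic carbon. For the measured compounds named here, no measured step touches this position, so the only guide is the spread seen between compound 2 and compound 1. Compound 3 is therefore expected to change little, and the step of a 1.1-fold higher number from compound 2 to compound 3 (0.05 log units; within the scatter) is estimated to stay within the scatter. Compound 3 is estimated at 400 nM, within a range of 130 nM to 1200 nM.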

Compound 3, half-maximal inhibitory concentration: 8070 nM
Compound 3: the middle estimate sits 20-fold (1.30 log units) below what was measured; measured number above the stated range.
By their numbers in this assay, from the lowest: compound 2; then compound 1; then compound 3.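

Methoxy in place of hydrogen on this aromatic carbon, ortho to a large group and para to a hydroxycarbamoyl group, is not a neutral change: a 22-fold higher number from compound 2 to compound 3 (1.35 log units; beyond the scatter) in this assay is a large step toward weaker inhibition. The position therefore responds to substitution, which the earlier pair could not show, as it varied only hexyl and 4-chlorophenyl. No measurement on hand accounts for this loss.

From the compounds shown here alone, whether the loss is specific to methoxy remains open, and fluorine, hydroxy or ethoxy on this carbon would test that. Also open, going by these compounds, is whether methoxy here has a similar effect with the hexyl group of compound 1.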